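The source may hold more compounds than are shown below. What is called first, only, known or untested is meant among the compounds shown, and "the series" means these compounds.

Measured so far:
compound 1 `CN(C)CCCOc1ccc(CN2CC[C@H](NC(=O)c3ccco3)C2)cc1` — < 10000 nM
compound 2 `CC(=O)N[C@H]1CCN(Cc2ccc(OCCCN(C)C)cc2)C1` — < 10000 nM
compound 3 `CC(C)C[C@H](NC(=O)c1cc2ccccc2[nH]1)C(=O)N[C@H]1CCN(Cc2ccc(OCCCN(C)C)cc2)C1` — 501 nM

For the measured compounds named here, in an assay on HEK293 cells for binding affinity to Urotensin-2 receptor (Homo sapiens), read by radioligand binding (a higher number here means a weaker inhibitor, a lower number a stronger inhibitor), compound 3 gives 501 nM, the only number among the three values. Compound 1 gives < 10000 nM, which is a limit of this assay and not a number. Compound 2 gives < 10000 nM, again a limit. Going by the values given here, the single step between measured compounds, a step that the two limits leave unreadable from compound 1 to compound 2, is therefore not readable, since both ends sit at the limit of < 10000 nM in this assay, at which 2 of the 3 values shown sit. Among the compounds with values here, compound 3 thus stands alone as the reference point, with no measured step on any side of it.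

Compound 4 `CC(C)C[C@H](NC(=O)Nc1ccccc1)C(=O)N[C@H]1CCN(Cc2ccc(OCCCN(C)C)cc2)C1` differs from compound 3 by anilino in place of 1H-indol-2-yl on a carbonyl carbon. Within the data shown here, no measured pair touches this carbonyl-side group, so no step bears on the change, and the expectation rests only on the value of compound 3 and the size of the change. Compound 4 is expected at 1500 nM, with a range from 400 nM to 6000 nM. The expected step is a 3.0-fold higher number from compound 3 to compound 4 (0.48 log units; beyond the scatter), a modest loss set with wide bounds for lack of any precedent.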

Compound 4, inhibition constant: 1000 nM
The estimate for compound 4 lay 1.5-fold (0.18 log units) above the measured number, within the range that was stated.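

In this assay, for the compounds shown here, anilino in place of 1H-indol-2-yl on the carbonyl carbon gives a 2.0-fold higher number from compound 3 to compound 4 (0.30 log units; within the scatter), the first readable step. This position therefore does not depend on the 1H-indol-2-yl group for this level of binding: a single six-membered aromatic ring of carbon only, joined through an amide-type nitrogen, cannot be told apart from the larger group here. Nothing in the available data accounts for this result.

As far as these compounds go, whether a cyclohexylamino group in place of anilino, or a carboxylic acid on the anilino ring, would stay within the scatter of compound 4 remains open. The step from compound 1 to compound 2 cannot be read, so the effect of the carbonyl-side group in that shorter pair also remains open: the limit of < 10000 nM in this assay, at which 2 of the 4 values shown sit.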